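Swapping Methyl for Fluoro on Compound 1

The source may hold more compounds than are shown below. What is called first, only, known or untested is meant among the compounds shown, and "the series" means these compounds.

Compound 1 `Cc1ccc(CS(=O)(=O)/C(=C/c2c[nH]c3ccccc23)C(=O)c2ccc(Cl)cc2)cc1` is the weakest of the three compounds measured in a functional assay on DU-145 cells (Homo sapiens) for inhibition, read by trypan blue exclusion, with a stated time of 96 h (on this read-out higher numbers stand for weaker inhibition of growth and lower numbers for stronger inhibition of growth), where compound 1 gives 25000 nM. Compound 2 `Cc1ccc(CS(=O)(=O)/C(=C/c2cccc(Cl)c2Cl)C(=O)c2ccc(Cl)cc2)cc1` gives 1000 nM in this assay, and compound 3 `Cc1ccc(CS(=O)(=O)/C(=C/c2cc(C)ccc2C)C(=O)c2ccc(Cl)cc2)cc1` gives 1000 nM. Both sit well away from compound 1: a 25-fold lower number from compound 1 to compound 2 (1.40 log units; beyond the scatter) and a 25-fold lower number from compound 1 to compound 3 (1.40 log units; beyond the scatter), while no change at the digits printed from compound 2 to compound 3 (within the scatter). Compound 4 `O=C(/C(=C\c1c[nH]c2ccccc12)S(=O)(=O)Cc1ccc(F)cc1)c1ccc(Cl)cc1` differs from compound 1 at another place entirely: fluoro in place of methyl on an aromatic carbon. The change sits on an aromatic carbon of a six-membered aromatic ring of carbon only, para to a large group. For the measured compounds named here, none of the measured steps touches this ring; all three concern the group on the double-bonded chain carbon bound to a double-bonded chain carbon. The data thus contain nothing that points to a step in either direction, and for compound 4 the expected outcome in this assay is a change within the scatter, no change at the digits printed from compound 1 to compound 4 (within the scatter). The estimate for compound 4 is 25000 nM, with a range from 8000 nM to 70000 nM.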

Compound 4, concentration for 50% growth inhibition: 50000 nM
Compound 4: middle estimate off by 2.0-fold (0.30 log units), on the low side; the range from low to high includes it.
By their numbers in this assay, from the lowest: compounds 2 and 3 (each within the scatter of the next); then compounds 1 and 4 (each within the scatter of the next).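

In this assay, the step at this position is a 2.0-fold higher number from compound 1 to compound 4 (0.30 log units; within the scatter), so with the 1H-indol-3-yl group held in place, 4-fluorobenzyl and 4-methylbenzyl cannot be told apart. The earlier compounds shown here showed large steps only at the group on the double-bonded chain carbon and gave no reading at all on this ring, which this pair now supplies for one single-atom exchange on an aromatic carbon. Nothing available bears on what lies behind this result.

As far as these compounds go, whether an amine or a carboxylic acid on this same aromatic carbon would give a step beyond the scatter remains open. So does whether fluoro in place of methyl would read the same on compound 2 or compound 3, which carry other groups on the double-bonded chain carbon.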